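This account rests on a few compounds, and the source may have more. Where it says the series, first, only, none or still open, it means among the compounds named here.

Of the compounds shown here, three built on one shared core have been measured in a functional assay on PC-3 cells (Homo sapiens) for antiproliferative activity, read by sulforhodamine B assay, with a stated time of 3 days; on this read-out higher numbers stand for an effect only at larger amounts of compound and lower numbers for an effect already at smaller amounts. Compound 1 `CCCC1=C(OC)C(CCC)(CCC)C(=O)/C(=C(O)\C=C\c2ccccc2)C1=O` gives 8.2 uM. Compound 2 `CCCC1=C(OC)C(CCC)(CCC)C(=O)/C(=C(O)\C=C\c2ccc(I)cc2)C1=O`, which carries iodo in place of hydrogen on an aromatic carbon, gives 2.8 uM, and that change is a 2.9-fold lower number from compound 1 to compound 2 (0.47 log units; beyond the scatter). Compound 3 `CCCCOC1=C(CCC)C(=O)/C(=C(O)/C=C/c2ccccc2)C(=O)C1(CCC)CCC` gives 9.6 uM; its change from compound 1, propyl in place of hydrogen on a saturated chain carbon bound to an oxygen on an unsaturated carbon, is a 1.2-fold higher number from compound 1 to compound 3 (0.07 log units; within the scatter). Among these three numbers compound 2 holds the lowest, and its distance to compound 1 as well as to compound 3 lies beyond the scatter.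

Compound 4 `CCCC1=C(OC)C(CCC)(CCC)C(=O)/C(=C(O)\C=C\c2ccc(Br)cc2)C1=O` has not yet been measured. It differs from compound 2 by bromo in place of iodo on an aromatic carbon. Among the compounds with values here, the one measured step that touches this aromatic carbon is a 2.9-fold lower number from compound 1 to compound 2 (0.47 log units; beyond the scatter), which shows that iodo there lowered the number beyond the scatter; the step of a 1.2-fold higher number from compound 1 to compound 3 (0.07 log units; within the scatter) concerns another part of the core and shows nothing beyond the scatter. Within the data shown here, no measured pair sets one halogen against another at this position, so the size of the exchange remains open. Compound 4 is therefore expected to stay close to compound 2, with an expected step of a 1.3-fold higher number from compound 2 to compound 4 (0.10 log units; within the scatter) that should remain within the scatter. Compound 4 is estimated at 3.5 uM, with a range from 1.5 uM to 8 uM.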

Compound 4, concentration for half-maximal effect: 4.7 uM
Compound 4: the middle estimate sits 1.3-fold (0.13 log units) below what was measured, and the stated range covers the measured number.
By their numbers in this assay, from the lowest: compounds 2, 4, 1 and 3 (each within the scatter of the next, the first and the last beyond it).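

In this assay, within the data shown here, the exchange of iodo for bromo on this aromatic carbon comes to a 1.7-fold higher number from compound 2 to compound 4 (0.22 log units; within the scatter) and so does not separate the two halogens, a comparison the earlier compounds could not offer. Measured against hydrogen on the same carbon, bromo gives a 1.7-fold lower number from compound 1 to compound 4 (0.24 log units; within the scatter) while iodo gives a 2.9-fold lower number from compound 1 to compound 2 (0.47 log units; beyond the scatter) and thus only iodo has a step from hydrogen that lies beyond the scatter. Compound 4 therefore stands within the scatter of both compound 1 and compound 2 even though those two lie beyond the scatter of each other, so the numbers cannot place bromo with either iodo or hydrogen at this position.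

On these data alone, what chloro, fluoro, methoxy or an amine would do on this aromatic carbon remains open, as does any trend across the halogens, which two halogens alone cannot establish. As far as these compounds go, it is also open whether the step seen with iodo carries over to the core of compound 3, and whether it holds in any assay on other cells. Nothing available gives a reason for these numbers.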